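A few compounds are considered here, and "the series" means these few. Any claim that something is new, unique, unknown or untested is made for them only; others in the source may bear on it.

Of the compounds shown here, three sharing one core have been measured so far. Compound 1 `Cc1ccc(NC(=O)c2ccc(/N=N\c3c[nH]c4ccccc34)cc2)cc1` gives 42400 nM in a functional assay on MCF7 cells (Homo sapiens) for inhibition, read by MTT assay, with a stated time of 72 h; on this read-out higher numbers stand for weaker inhibition and lower numbers for stronger inhibition. Compound 2 `O=C(Nc1ccccc1[N+](=O)[O-])c1ccc(/N=N\c2c[nH]c3ccccc23)cc1` gives 101000 nM in this assay, and compound 3 `O=C(Nc1ccccc1Cl)c1ccc(/N=N\c2c[nH]c3ccccc23)cc1` gives 112000 nM. Compound 3 stands with the highest number of the three: its value and that of compound 2 lie within the scatter of each other, while the step of a 2.6-fold higher number from compound 1 to compound 3 (0.42 log units; beyond the scatter) lies beyond it, as does the step of a 2.4-fold higher number from compound 1 to compound 2 (0.38 log units; beyond the scatter).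

Compound 4 `Cc1ccc(C)c(NC(=O)c2ccc(/N=N\c3c[nH]c4ccccc34)cc2)c1` has not yet been measured in this assay. It differs from compound 3 in one place: 2,5-dimethylphenyl in place of 2-chlorophenyl on an amide-type nitrogen. The step that bears most directly on this change is a 2.6-fold higher number from compound 1 to compound 3 (0.42 log units; beyond the scatter), the exchange of a methyl-bearing phenyl for the 2-chlorophenyl, which raised the number. The step of a 1.1-fold higher number from compound 2 to compound 3 (0.04 log units; within the scatter) shows that chloro and nitro on that ring behave alike. Going back from 2-chlorophenyl to a phenyl carrying only methyl groups therefore points toward a lower number in this assay, though the second methyl of compound 4 has no counterpart among the measured compounds, so the size is uncertain. For compound 4 the expected step is a 1.9-fold lower number from compound 3 to compound 4 (0.27 log units; within the scatter), and its value is estimated at 60000 nM, within a range from 25000 nM to 150000 nM.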

Compound 4, half-maximal inhibitory concentration: 29900 nM
The estimate for compound 4 lay 2.0-fold (0.30 log units) above the measured number; measured number inside the range.
By their numbers in this assay, from the lowest: compounds 4 and 1 (each within the scatter of the next); then compounds 2 and 3 (each within the scatter of the next).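

In this assay, the step of a 3.7-fold lower number from compound 3 to compound 4 (0.57 log units; beyond the scatter) and the step of a 3.4-fold lower number from compound 2 to compound 4 (0.53 log units; beyond the scatter) show that replacing chloro or nitro with the two methyl groups of 2,5-dimethylphenyl on the amide-type nitrogen goes with a lower number, while the step of a 1.4-fold lower number from compound 1 to compound 4 (0.15 log units; within the scatter) leaves compound 4 level with compound 1. Among the earlier compounds, only 2-chlorophenyl and 2-nitrophenyl gave the higher numbers, so the 2 in their names could not be separated from the chloro or nitro group they carry; 2,5-dimethylphenyl also has a group at 2, yet among these four compounds the higher numbers stay with chloro and nitro and the lower numbers with the methyl-bearing rings. Nothing shown here gives a measured reason for this difference.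

The compounds shown leave open what each methyl of 2,5-dimethylphenyl contributes on its own, as 2-methylphenyl and 3-methylphenyl are not among them. They also leave open whether a methoxy or an amino group on this ring would fall with the methyl-bearing compounds or with those carrying chloro and nitro.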